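From Methyl to Methoxy on a Shared Core

The compounds below may be only part of what the source reports. "The series", "measured", "known", "first", "only" and "open" are said of these compounds alone.

In a functional assay on KB cells (Homo sapiens) for antiproliferative activity, read by sulforhodamine B assay, with a stated time of 3 days (a higher number here means that more compound is needed for the effect, a lower number that less compound is needed), compound 1 (`CCC1=C(O)c2c(oc(-c3ccc(C)cc3)cc2=O)C(CC)(CC)C1=O`) gives 39.2 uM and compound 2 (`CCC1=C(O)c2c(oc(-c3ccccc3C)cc2=O)C(CC)(CC)C1=O`) gives 40.9 uM so the two stand within the usual scatter of each other. Within the data shown here, their one measured step is a 1.0-fold higher number from compound 1 to compound 2 (0.02 log units; within the scatter) with 2-methylphenyl in place of 4-methylphenyl. Compound 3 (`CCC1=C(O)c2c(oc(-c3ccccc3OC)cc2=O)C(CC)(CC)C1=O`) has methoxy in place of methyl on an aromatic carbon. Among the measured compounds shown here, no measured step covers this swap, so no change beyond the scatter is expected in this assay and no direction can be called. The expected step is a 1.1-fold lower number from compound 2 to compound 3 (0.03 log units; within the scatter) at most modest. Compound 3 is estimated at 38 uM with a likely range from 17 uM to 85 uM overall.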

Compound 3, concentration for half-maximal effect: 40.8 uM
Beside the measured number, compound 3's estimate is 1.1-fold (0.03 log units) below it; the range from low to high includes it.
By their numbers in this assay, from the lowest: compounds 1, 3 and 2 (each within the scatter of the next).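

In this assay, methoxy in place of methyl on an aromatic carbon, ortho to a large group, gives a 1.0-fold lower number from compound 2 to compound 3 (0.00 log units; within the scatter), so this swap, which brings in one oxygen, stays within the scatter. Putting 2-methoxyphenyl in place of 4-methylphenyl gives a 1.0-fold higher number from compound 1 to compound 3 (0.02 log units; within the scatter), also within the scatter, so all three compounds read alike in this assay. Nothing measured here explains why these numbers stay together.

From the compounds shown here alone, whether an amine or a carboxylic acid at this place would move the number beyond the scatter remains open. So does how a 4-methoxyphenyl group would compare with the 4-methylphenyl group of compound 1.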